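This account rests on a few compounds, and the source may have more. Where it says the series, first, only, none or still open, it means among the compounds named here.

Measured compounds:
compound 1 `O=C(Cc1cccnc1)c1cc2c(Cl)cc(Cl)cc2[nH]1` — "not active" (no number reported)
compound 2 `O=C(Cc1cccnc1)c1cc2c(F)cccc2[nH]1` — 12%

Compound 1, in an in vitro assay on P815B cells for inhibition of Indoleamine 2,3-dioxygenase 1 (Mus musculus), tested at 20 uM (on this read-out lower numbers stand for less inhibition and higher numbers for more inhibition at the one concentration tested (going by the name of the read-out)), is reported only as "not active" (no number reported), with no number given. Compound 2, in this assay, gives 12%, the only number shown, the one further entry carrying no figure.

Compound 3 `O=C(Cc1cccnc1)c1cc2c(O)cccc2[nH]1` differs from compound 2 by hydroxy in place of fluoro on an aromatic carbon. Going by the values given here, no measured pair shows this change, so the step from compound 2 to compound 3 in this assay is expected to stay within the scatter, as a number 3 percentage points higher from compound 2 to compound 3 (within the scatter). Compound 3 is therefore estimated at 15%, in a range from 0% to 35%.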

Compound 3, a percentage reported as inhibition, at one concentration (the size of the read-out at that concentration, not a potency): "not active" (no number reported)
Compound 3 has no reported number here; there is nothing to compare the estimate with.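

Compound 3, like compound 1, is reported without a number in this assay, so no step can be read from compound 2 to compound 3. The compounds shown leave open what hydroxy in place of fluoro does to inhibition, and no other data given here bear on this result.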